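Cyclopropyl in Place of Phenyl on the Shared Core

The compounds below may be only part of what the source reports. "The series", "measured", "known", "first", "only" and "open" are said of these compounds alone.

Compound 1 `COc1nc2ccc(Br)cc2cc1C(c1ccccc1)n1cc(-c2ccccc2)nn1` gives 13.7% in an ADME assay on SK-OV-3 cells (Homo sapiens) for cytotoxicity, read by sulforhodamine B assay, with a stated time of 48 h, tested at 10 uM (a higher number here means more inhibition at the concentration tested (going by the name of the read-out), a lower number less inhibition), and on the two numbers recorded it stands alongside compound 2, within the scatter. Compound 2 `COc1nc2ccc(Br)cc2cc1C(c1ccccc1)n1cc(CCCCCO)nn1` gives 8.69% in this assay, the step of a number 5 percentage points lower from compound 1 to compound 2 (within the scatter) being within the scatter. Compound 3 `COc1nc2ccc(Br)cc2cc1C(c1ccccc1)n1cc(C2CC2)nn1` differs from compound 1 thus: cyclopropyl in place of phenyl on an aromatic carbon. Among the compounds with values here, only the step from compound 1 to compound 2 bears on this change, and since that step was within the scatter, no step beyond the scatter is expected in this assay. The expected step is a number 2.7 percentage points lower from compound 1 to compound 3 (within the scatter). Compound 3 is therefore estimated at 11%, with a range from 0% to 24%.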

Compound 3, a percentage reported as inhibition, at one concentration (the size of the read-out at that concentration, not a potency): 3.52%
Compound 3: middle estimate off by 7.5 percentage points, on the high side, within the range that was stated.
By their numbers in this assay, from the lowest: compounds 3, 2 and 1 (each within the scatter of the next, the first and the last beyond it).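

In this assay, cyclopropyl in place of phenyl on this aromatic carbon gives a number 10.2 percentage points lower from compound 1 to compound 3 (beyond the scatter), the first step shown at this position to clear the scatter. The two non-aromatic groups do not separate, with a number 5.2 percentage points lower from compound 2 to compound 3 (within the scatter) for cyclopropyl in place of 5-hydroxypentyl. No measurement at hand offers an explanation for the step away from phenyl. As far as these compounds go, whether an amine or a carboxylic acid on this carbon would shift the number in this assay remains open. So does whether any group here, such as a naphthyl ring, would give a number beyond the scatter above that of compound 1.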